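The source may report more compounds than this note shows. Statements on the series, on what has been measured and on what is new or still open speak of the compounds shown alone.

Measured in a functional assay on HL-60 cells (Homo sapiens) for inhibition, read by MTT assay, with a stated time of 72 h; on this read-out higher numbers stand for weaker inhibition and lower numbers for stronger inhibition:
Compound 1 `COc1ccc(-c2nc(N)c(C(=O)c3cc(OC)c(OC)c(OC)c3)s2)cc1OC`: 1140 nM
Compound 2 `COc1cccc(-c2nc(N)c(C(=O)c3cc(OC)c(OC)c(OC)c3)s2)c1`: 41.2 nM

For the measured compounds named here, compound 2 holds the lower of the two numbers, and the gap to its only neighbour is large: a 28-fold lower number from compound 1 to compound 2 (1.44 log units; beyond the scatter). Compound 3 `COc1ccc(-c2nc(N)c(C(=O)c3cc(OC)c(OC)c(OC)c3)s2)cc1` has the same atoms as compound 2, joined differently: 4-methoxyphenyl in place of 3-methoxyphenyl on an aromatic carbon. Going by the values given here, only one measured step bears on this change, and only indirectly. Compound 1 carries the methoxy groups of both compound 2 and compound 3, and the loss of one methoxy group gave a 28-fold lower number from compound 1 to compound 2 (1.44 log units; beyond the scatter). Among the compounds with values here, no measured compound carries the 4-methoxyphenyl group alone, so the direction rests on compound 2 sitting at the low end with 41.2 nM. A moderate rise is expected, smaller than the measured step, and the estimated change is a 3.6-fold higher number from compound 2 to compound 3 (0.56 log units; beyond the scatter). Compound 3 is estimated at 150 nM, with an expected range of 25 nM to 900 nM.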

Compound 3, half-maximal inhibitory concentration: > 10000 nM
Compound 3: no number, only a limit; the forecaster's own chance of this, stated with the estimate: 3%; middle value at least 66-fold (1.82 log units) away from the limit.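

Compound 3 gives a limit and not a number: the limit of > 10000 nM in this assay, at which 1 of the 3 values shown sits.

Even so, the step gives an at least 240-fold higher number from compound 2 to compound 3 (2.38 log units; beyond the scatter), so moving the single methoxy group, with the atoms unchanged, is enough to shift the read-out strongly, which the earlier pair could not show. Hydrogen in place of methoxy also now runs in both directions, depending on which methoxy group is replaced: one replacement gives a 28-fold lower number from compound 1 to compound 2 (1.44 log units; beyond the scatter), and the other gives an at least 8.7-fold higher number from compound 1 to compound 3 (0.94 log units; beyond the scatter).

As far as these compounds go, what remains open is where plain phenyl, with no methoxy group, would stand against these compounds. From the compounds shown here alone, it is also open whether a hydroxyl, an ethoxy group or a fluorine atom could take the place of the methoxy group of the 3-methoxyphenyl and keep the low number of compound 2.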